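Swapping the Aryl Group on the Piperazine Nitrogen

This account rests on a few compounds, and the source may have more. Where it says the series, first, only, none or still open, it means among the compounds named here.

Measured compounds:
compound 1, `CC1(c2ccccc2)CC(=O)N(CC(=O)N2CCN(c3ccccc3)CC2)C1=O`: 300 mg/kg
compound 2, `COc1ccccc1N1CCN(C(=O)CN2C(=O)CC(C)(c3ccccc3)C2=O)CC1`: 100 mg/kg

In a functional assay on the whole organism (strain CD-1) with Mus musculus as the target, in the maximal electroshock model, with a stated time of 0.5 h (on this read-out higher numbers stand for an effect only at larger amounts of compound and lower numbers for an effect already at smaller amounts), compound 2 gives 100 mg/kg, the lowest of the two numbers shown; its nearest neighbour is compound 1, which in this assay gives 300 mg/kg. Among the measured compounds shown here, the single measured step, a 3.0-fold lower number from compound 1 to compound 2 (0.48 log units; beyond the scatter), is modest and beyond the scatter.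

Compound 3, `CC1(c2ccccc2)CC(=O)N(CC(=O)N2CCN(c3ccc(F)cc3)CC2)C1=O`, has not yet been measured. It differs from compound 2 by 4-fluorophenyl in place of 2-methoxyphenyl on an amine nitrogen in a ring. For the measured compounds named here, no measured step bears directly on this change: the one step on record concerns methoxy in place of hydrogen on an aromatic carbon, not 4-fluorophenyl in place of 2-methoxyphenyl. Since compound 1 and compound 2 together span only a modest range, compound 3 is expected to land between them or close to compound 2, with the step of a 2.0-fold higher number from compound 2 to compound 3 (0.30 log units; within the scatter) as the estimated outcome. Compound 3 is thus expected to give about 200 mg/kg, within a range from 75 mg/kg to 400 mg/kg.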

Compound 3, minimum effective dose: 100 mg/kg
The estimate for compound 3 lay 2.0-fold (0.30 log units) above the measured number; the range from low to high includes it.
By their numbers in this assay, from the lowest: compounds 2 and 3 (each within the scatter of the next); then compound 1.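

In this assay, the gain at this amine nitrogen in a ring is not tied to methoxy: fluoro in place of hydrogen gives a 3.0-fold lower number from compound 1 to compound 3 (0.48 log units; beyond the scatter) and so matches the size of the earlier step, a 3.0-fold lower number from compound 1 to compound 2 (0.48 log units; beyond the scatter), on the same phenyl group. The direct exchange of 2-methoxyphenyl for 4-fluorophenyl gives no change at the digits printed from compound 2 to compound 3 (within the scatter), so these two groups cannot be told apart on this read-out. Nothing measured alongside these numbers accounts for them.

The compounds shown leave open whether the place of the group on the phenyl ring matters, since methoxy and fluoro each appear at one place only. They also leave open whether chloro, trifluoromethyl or a carboxylic acid on that ring would give a similar number.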